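Hydrogen for chloro on compound 1: working notes

A few compounds are considered here, and "the series" means these few. Any claim that something is new, unique, unknown or untested is made for them only; others in the source may bear on it.

Measured so far in a functional assay on A549 cells (Homo sapiens) for antiproliferative activity, read by MTT assay, with a stated time of 72 h (on this read-out higher numbers stand for weaker inhibition and lower numbers for stronger inhibition), lower numbers meaning stronger inhibition:
- compound 1 `COc1cc(-n2ncnc2-c2ccc(Cl)cc2)cc(OC)c1OC` gives > 10000 nM (a limit, not a number)
- compound 2 `CCOc1ccc(-c2ncnn2-c2cc(OC)c(OC)c(OC)c2)cc1Cl` gives 10 nM (a number)
- compound 3 `COc1cc(-c2ncnn2-c2ccccc2)cc(OC)c1OC` gives > 10000 nM (a limit, not a number)

Only a limit is known for compound 1, so it has no exact place on the scale. It shares that position with compound 3, as the limit of > 10000 nM in this assay, at which 2 of the 3 values shown sit, records. Compound 2 is the only one of the three with a number.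

Compound 4 `COc1cc(-n2ncnc2-c2ccccc2)cc(OC)c1OC` is not yet measured. It comes from compound 1 by hydrogen in place of chloro on an aromatic carbon, para to a large group, so that 4-chlorophenyl becomes phenyl.

Among the measured compounds shown here, no measured step covers this change, so the expectation rests on the standing of compound 1 alone. The standing of compound 1, > 10000 nM, is a limit. The expected result is no step beyond the scatter in this assay, in either direction, and most likely another limit. The estimated step is a step that the limit leaves unreadable from compound 1 to compound 4 and it is expected to be small. For compound 4 the estimated value is 15000 nM, with an expected range from 2500 nM to 60000 nM in the same read-out.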

Compound 4, half-maximal inhibitory concentration: > 10000 nM
Compound 4 was reported as a limit (the forecaster's own chance of this, stated with the estimate: 80%); the middle value lies beyond the limit too.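

In this assay compound 4, like compound 1, is reported only as a limit, so no step can be read between compound 1 and compound 4: the limit of > 10000 nM in this assay, at which 3 of the 4 values shown sit. The compounds shown leave open whether hydrogen in place of chloro on the shared core changes the antiproliferative activity at all, with no number for either compound.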